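Swapping the ring amine on the shared core of compound 2

The source may hold more compounds than are shown below. What is called first, only, known or untested is meant among the compounds shown, and "the series" means these compounds.

Measured so far:
Compound 1 `CCCN(Cc1c(C(F)(F)F)nc2n1CCCN2c1c(C)cc(C)cc1C)CC1CC1`: 32 nM
Compound 2 `Cc1cc(C)c(N2CCCn3c2nc(C(F)(F)F)c3CN2CC=CCC2)c(C)c1`: 364 nM

These two compounds were tested in an in vitro assay on IMR-32 cells for displacement of a labelled ligand from corticotropin-releasing factor receptor 1 (Homo sapiens); on this read-out higher numbers stand for weaker inhibition and lower numbers for stronger inhibition. Compound 2 gives the higher of the two numbers; the step is an 11-fold higher number from compound 1 to compound 2 (1.06 log units; beyond the scatter), a step that exchanged the ring amine group attached to the saturated chain carbon on the shared core.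

Compound 3 `Cc1cc(C)c(N2CCCn3c2nc(C(F)(F)F)c3CN2CCCN(C)CC2)c(C)c1` keeps everything of compound 2 except that same ring amine: a group of 8 heavy atoms (6 carbon, 2 nitrogen; one seven-membered non-aromatic ring with 2 hetero atoms) in place of a group of 6 heavy atoms (5 carbon, 1 nitrogen; one six-membered non-aromatic ring with 1 hetero atom), on a saturated chain carbon bound to an aromatic carbon. Among the compounds with values here, no measured step exchanges one ring amine for another, so the only guide is that the step from compound 1 to compound 2 shows this position can move the number a lot. The 4-methyl-1,4-diazepan-1-yl group is a ring amine like the one it replaces, so the expected change from compound 2 to compound 3 is small, a 1.1-fold higher number from compound 2 to compound 3 (0.04 log units; within the scatter), with wide uncertainty. Compound 3 is therefore estimated at 400 nM, between 100 nM and 1500 nM.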

Compound 3, inhibition constant: > 5000 nM
Compound 3 ended at the assay's limit; the forecaster's own chance of this, stated with the estimate: 5%; middle value at least 12-fold (1.09 log units) away from the limit.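

Compound 3 stands at a limit of this assay, not at a measured number: the limit of > 5000 nM in this assay, at which 1 of the 3 values shown sits. Even so, the change is an at least 13-fold higher number from compound 2 to compound 3 (1.13 log units; beyond the scatter), which shows that at this place, a saturated chain carbon bound to an aromatic carbon, one ring amine cannot simply stand in for another. Measured against the (cyclopropylmethyl)(propyl)amino group, the change is an at least 150-fold higher number from compound 1 to compound 3 (2.19 log units; beyond the scatter), so both ring amines shown give weaker inhibition than that open-chain amine.

Going by these compounds, whether the loss goes with the seven-membered ring or with the second ring nitrogen of the 4-methyl-1,4-diazepan-1-yl group stays open, as does the true number for compound 3. An azepane ring at the same place, seven-membered but with only one nitrogen, would separate these two features.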